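The compounds below may be only part of what the source reports. "The series", "measured", "known", "first", "only" and "open" are said of these compounds alone.

Among the measured compounds shown here, compound 3, `COc1c(CC(F)(F)F)cc(-n2ccc(=O)[nH]c2=O)c2ncc(-c3ccc(NS(C)(=O)=O)cc3)cc12`, gives 3.7 uL/min in an ADME assay on cells (Hepatocyte, Rattus norvegicus) for metabolic stability (on this read-out lower numbers stand for slow clearance and higher numbers for fast clearance), which places it second highest of the three compounds measured so far: its nearest neighbour is compound 2, `COc1c(C(F)(F)F)cc(-n2ccc(=O)[nH]c2=O)c2ncc(-c3ccc(NS(C)(=O)=O)cc3)cc12`, which gives 1.8 uL/min, and the furthest is compound 1, `COc1c(C(C)(C)C)cc(-n2ccc(=O)[nH]c2=O)c2ncc(-c3ccc(NS(C)(=O)=O)cc3)cc12`, which gives 20 uL/min. Compound 4, `COc1c(C2(C(F)F)CC2)cc(-n2ccc(=O)[nH]c2=O)c2ncc(-c3ccc(NS(C)(=O)=O)cc3)cc12`, differs from compound 3 in one place: a group of 6 heavy atoms (4 carbon, 2 fluorine; one three-membered non-aromatic ring of carbon only) in place of a group of 5 heavy atoms (2 carbon, 3 fluorine; no ring), on an aromatic carbon. For the measured compounds named here, two measured steps bear on this change. From compound 1 to compound 3 the number fell, a 5.4-fold lower number from compound 1 to compound 3 (0.73 log units; beyond the scatter), and from compound 2 to compound 3 it rose, a 2.1-fold higher number from compound 2 to compound 3 (0.31 log units; beyond the scatter). The group entering in compound 4 carries more carbon and less fluorine than the one it replaces, so a modest rise toward the number of compound 1 is expected, a 1.6-fold higher number from compound 3 to compound 4 (0.21 log units; within the scatter). Compound 4 is therefore estimated at 6 uL/min, within 2.5 uL/min to 15 uL/min.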

Compound 4, intrinsic clearance in a liver preparation (reported as CLH), per the amount of preparation that the assay uses: 1.7 uL/min
Compound 4: middle estimate off by 3.5-fold (0.55 log units), on the high side; measured number below the stated range.
By their numbers in this assay, from the lowest: compounds 4 and 2 (each within the scatter of the next); then compound 3; then compound 1.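

In this assay, the group with the three-membered ring carries more carbon and less fluorine than 2,2,2-trifluoroethyl, yet the number fell (a 2.2-fold lower number from compound 3 to compound 4 (0.34 log units; beyond the scatter)). It shares its carbon count with tert-butyl but lies far lower (a 12-fold lower number from compound 1 to compound 4 (1.07 log units; beyond the scatter)), and it stands level with trifluoromethyl (a 1.1-fold lower number from compound 2 to compound 4 (0.02 log units; within the scatter)), so neither the carbon count nor the fluorine count alone orders these four compounds. Nothing shown accounts for these differences. Open, on these data alone, is whether the three-membered ring without fluorine, a plain difluoromethyl group or an amine at this position would give a similarly low number.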